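Carbamoyl in place of cyano on the shared core

The compounds below may be only part of what the source reports. "The series", "measured", "known", "first", "only" and "open" are said of these compounds alone.

In a functional assay on the whole organism with Rattus norvegicus as the target (a lower number here means that less compound is needed, a higher number that more compound is needed for the effect), compound 1 `CCCCn1c(=N)sc2cc(OC(F)(F)F)ccc21` gives 10 mg/kg, while compound 2 `N#CCn1c(=N)sc2cc(OC(F)(F)F)ccc21` gives 3.5 mg/kg, the lower of the two numbers. Compound 3 `N=c1sc2cc(OC(F)(F)F)ccc2n1CC(N)=O` carries carbamoyl in place of cyano on a saturated chain carbon bound to an aromatic nitrogen. Among the compounds with values here, the only measured step at this place, a 2.9-fold lower number from compound 1 to compound 2 (0.46 log units; beyond the scatter), is modest and involves no carbamoyl, so it offers limited guidance. A change of similar size toward a higher number is expected in this assay. The expected change is a 2.3-fold higher number from compound 2 to compound 3 (0.36 log units; beyond the scatter). For compound 3 the estimate is 8 mg/kg, with an expected range from 2.5 mg/kg to 25 mg/kg.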

Compound 3, dose for half-maximal effect: 7 mg/kg
The estimate for compound 3 lay 1.1-fold (0.06 log units) above the measured number, and the stated range covers the measured number.
By their numbers in this assay, from the lowest: compounds 2, 3 and 1 (each within the scatter of the next, the first and the last beyond it).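

In this assay, carbamoyl in place of cyano gives a 2.0-fold higher number from compound 2 to compound 3 (0.30 log units; within the scatter) and carbamoyl in place of propyl gives a 1.4-fold lower number from compound 1 to compound 3 (0.15 log units; within the scatter) at this chain carbon, so compound 3 cannot be told apart from either neighbour, although those two differ beyond the scatter. Bringing in a hydrogen-bond donor here therefore produces no step beyond the scatter. No available evidence accounts for this. The compounds shown leave open how a carboxylic acid or an amine at this place would read, and whether a longer chain carrying the carbamoyl would separate from compound 2.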